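This account rests on a few compounds, and the source may have more. Where it says the series, first, only, none or still open, it means among the compounds named here.

The measured compounds and their values:

Compound 1, `NC(=O)c1cc(-c2cccc(OC(=O)NC3CCCCC3)c2)n(-c2ccccc2)n1`, gives 169 nM in an assay on isolated protein for inhibition of Fatty-acid amide hydrolase 1 (Homo sapiens), read by fluorescence, with a stated time of 30 min; a higher number here means a weaker inhibitor, a lower number a stronger inhibitor.
Compound 2, `NC(=O)c1cc(-c2cccc(OC(=O)NC3CCCCC3)c2)n(-c2ccc(Cl)cc2)n1`, gives 174 nM in this assay.
Compound 3, `NC(=O)c1cc(-c2ccc(OC(=O)NC3CCCCC3)cc2)n(-c2ccccc2)n1`, gives 71 nM in this assay.

Compound 1 and compound 2 share one core and differ by a single change, (chloro in place of hydrogen on an aromatic carbon). That change left the result essentially where it was: a 1.0-fold higher number from compound 1 to compound 2 (0.01 log units; within the scatter). Compound 3 is built from the same atoms as compound 1, joined differently; the difference between the two cores is not broken down here. Compound 3 sits at the lowest number of the three, and its distance from compound 1 and from compound 2 is beyond the scatter.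

Compound 4, `NC(=O)c1cc(-c2ccc(OC(=O)NC3CCCCC3)cc2)n(-c2ccc(Cl)cc2)n1`, has not been measured. It stands to compound 3 as compound 2 stands to compound 1: the change is chloro in place of hydrogen on an aromatic carbon, and the place described for this change is the same as for the change from compound 1 to compound 2, so it is the same change applied to the core of compound 3.

Since the change from compound 1 to compound 2 gave a 1.0-fold higher number from compound 1 to compound 2 (0.01 log units; within the scatter), the expectation is that the step from compound 3 to compound 4 in this assay will be similar, namely a 1.0-fold higher number from compound 3 to compound 4 (0.01 log units; within the scatter). The estimate for compound 4 is therefore 72 nM, with a range from 35 nM to 145 nM, resting on the value of compound 3, 71 nM, and on that single earlier step.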

Compound 4, half-maximal inhibitory concentration: 172 nM
Beside the measured number, compound 4's estimate is 2.4-fold (0.38 log units) below it; the measured number lies above the stated range.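

On the core of compound 3, putting chloro in place of hydrogen, which turns phenyl into 4-chlorophenyl, weakened inhibition in this assay, giving a 2.4-fold higher number from compound 3 to compound 4 (0.38 log units; beyond the scatter). Taken alone, this step is beyond the scatter, while the same change on the core of compound 1 was not, yet the gap between the two steps is no larger than two such steps can show by chance: the same change on two cores in this assay, a 1.0-fold higher number (0.01 log units; within the scatter) from compound 1 to compound 2 and a 2.4-fold higher number (0.38 log units; beyond the scatter) from compound 3 to compound 4, 2.4-fold (0.37 log units) apart, within the scatter of two such steps. The data therefore do not show that the core decides what chloro does here, and they do not show that the step carries over unchanged from one core to the other, since two pairs in a single assay can settle neither reading.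

The compounds shown leave open whether another group in the same place, such as fluoro, bromo, methyl or methoxy, would give a step that stays the same across both cores or one that differs between them. They also leave open what the chloro step would be on a third core, and repeat measurements of these two pairs would be needed to narrow the gap between the two steps.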